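Series notes: triazolyl-to-tetrazolyl swap on the thioether

This account rests on a few compounds, and the source may have more. Where it says the series, first, only, none or still open, it means among the compounds named here.

Compound 1 `COc1ccc(-c2cs/c(=N/NC(=O)CSc3nnnn3C)n2-c2ccccc2)cc1` carries a methoxyphenyl group and has no result in a functional assay on C6 cells (Rattus norvegicus) for cytotoxicity, read by MTT assay, with a stated time of 24 h (on this read-out higher numbers stand for weaker inhibition and lower numbers for stronger inhibition), recorded as "not determined" (no result reported). Compound 2 `Cn1cnnc1SCC(=O)N/N=c1/scc(-c2ccc(C#N)cc2)n1-c1ccccc1` gives > 200 ug/mL in this assay, which is a limit of the assay and not a number. Compound 2 thus sits at the limit of > 200 ug/mL in this assay, at which 1 of the 2 values shown sits. Compound 3 `Cn1nnnc1SCC(=O)N/N=c1/scc(-c2ccc(C#N)cc2)n1-c1ccccc1` differs by 1-methyl-1H-tetrazol-5-yl in place of 4-methyl-4H-1,2,4-triazol-3-yl on a sulfur. Within the data shown here, no measured step is available for this change, so no shift beyond the scatter is expected, a step that the limit leaves unreadable from compound 2 to compound 3. Compound 3 is estimated at 250 ug/mL in this assay, within 150 ug/mL to 500 ug/mL, most likely again reported only as a limit.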

Compound 3, half-maximal inhibitory concentration: 23.3 ug/mL
Compound 3: middle estimate off by 11-fold (1.03 log units), on the high side, and the stated range ends above it.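

Among these compounds, on the sulfur, the attached ring matters in this assay: 1-methyl-1H-tetrazol-5-yl in place of 4-methyl-4H-1,2,4-triazol-3-yl gives an at least 8.5-fold lower number from compound 2 to compound 3 (0.93 log units; beyond the scatter), the first readable change at this position. Compound 2 stands at a limit of the assay, so this step gives only a lower bound on the size of the change: the limit of > 200 ug/mL in this assay, at which 1 of the 3 values shown sits.

Still open, as far as these compounds go, is whether the step carries over to the methoxyphenyl group of compound 1. Also open, from the compounds shown here alone, is how an amine or a carboxylic acid in place of the ring on the sulfur would read.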